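Moving from Amino to Nitro on the Shared Core

A few compounds are considered here, and "the series" means these few. Any claim that something is new, unique, unknown or untested is made for them only; others in the source may bear on it.

- Compound 1 `O=c1cc(N2CCN(CC3CCCCC3)CC2)sc2c(NO)cc(C(F)(F)F)cc12`: 19.1%
- Compound 2 `Nc1cc(C(F)(F)F)cc2c(=O)cc(N3CCN(CC4CCCCC4)CC3)sc12`: 0.9%

In an ADME assay on cells (Hepatocyte, Homo sapiens) for metabolic stability, with a stated time of 30 min (a higher number here means that more of the compound is left, a lower number that less of the compound is left), compound 2 is the lower of the two measured compounds, at 0.9%. Compound 3 `O=c1cc(N2CCN(CC3CCCCC3)CC2)sc2c([N+](=O)[O-])cc(C(F)(F)F)cc12` replaces the amino group of compound 2 with nitro on an aromatic carbon: nitro in place of amino on an aromatic carbon. For the measured compounds named here, only one measured step bears on this change, and it is modest and beyond the scatter: a number 18.2 percentage points lower from compound 1 to compound 2 (beyond the scatter). There, the compound with the amino group gave the lower number, so a rise of similar or somewhat larger size is expected. The expected step is a number 29.1 percentage points higher from compound 2 to compound 3 (beyond the scatter). Compound 3 is expected at 30%, with an estimated range from 8% to 60%.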

Compound 3, percent of the compound remaining: 82.4%
Compound 3: the middle estimate sits 52.4 percentage points below what was measured, and the stated range ends below it.
By their numbers in this assay, from the lowest: compound 2; then compound 1; then compound 3.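

Placing nitro on this aromatic carbon gives a number 81.5 percentage points higher from compound 2 to compound 3 (beyond the scatter) and a number 63.3 percentage points higher from compound 1 to compound 3 (beyond the scatter) in this assay. The group at this one position can therefore move the result much further than the amino and hydroxyamino pair alone showed, and both new steps are large. Nothing given here explains why nitro differs so strongly from the other two groups.

On these data alone, it remains open whether a nitrile or a methoxy group at this carbon would leave a similar amount of compound. As far as these compounds go, it is also open whether nitro would have the same effect on a different core.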